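Shifting a Hydroxyl Group Across Two Related Cores

A few compounds are considered here, and "the series" means these few. Any claim that something is new, unique, unknown or untested is made for them only; others in the source may bear on it.

Measured in a functional assay on HCT-15 cells (Homo sapiens) for cytotoxicity, read by CCK-8 assay and cell counting, with a stated time of 2 days; a higher number here means a weaker inhibitor, a lower number a stronger inhibitor:
Compound 1, `Oc1cccc(-c2cc(-c3ccc(Cl)cc3)nc(-c3ccccn3)c2)c1`: 13500 nM
Compound 2, `Oc1ccc(-c2cc(-c3ccc(Cl)cc3)nc(-c3ccccn3)c2)cc1`: 21300 nM
Compound 3, `Oc1ccc(-c2cc(-c3ccccc3)nc(-c3cccc(Cl)c3)c2)cc1`: 6100 nM

Compound 1 and compound 2 share a core and differ only in the change (3-hydroxyphenyl in place of 4-hydroxyphenyl on an aromatic carbon). In this assay this gave a 1.6-fold lower number from compound 2 to compound 1 (0.20 log units; within the scatter), so the two values cannot be told apart. Compound 3 sits on a different core; the difference between the two cores is not broken down here. Among the three measured compounds, compound 3 gives the lowest number, with both others beyond the scatter from it.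

Compound 4, `Oc1cccc(-c2cc(-c3ccccc3)nc(-c3cccc(Cl)c3)c2)c1`, is not yet measured. It arises from compound 3 by 3-hydroxyphenyl in place of 4-hydroxyphenyl on an aromatic carbon. The surroundings are not identical: in compound 2 the place is meta to a 4-chlorophenyl group and meta to a pyridin-2-yl group, whereas in compound 3 it is meta to a 3-chlorophenyl group and meta to a phenyl group. It is therefore the same kind of change, not the same change. Resting on compound 2 and compound 1, where the shift gave a 1.6-fold lower number from compound 2 to compound 1 (0.20 log units; within the scatter), a step of a 1.4-fold lower number from compound 3 to compound 4 (0.13 log units; within the scatter) is expected in this assay. Compound 4 is estimated at 4500 nM, expected between 2000 nM and 10000 nM.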

Compound 4, half-maximal inhibitory concentration: 2550 nM
The estimate for compound 4 lay 1.8-fold (0.25 log units) above the measured number; measured number inside the range.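

Putting 3-hydroxyphenyl in place of 4-hydroxyphenyl on the core of compound 3 gave a 2.4-fold lower number from compound 3 to compound 4 (0.38 log units; beyond the scatter) in this assay. Set beside the same change on the core of compound 1, the two steps cannot be told apart in size: the same change on two cores in this assay, a 1.6-fold lower number (0.20 log units; within the scatter) from compound 2 to compound 1 and a 2.4-fold lower number (0.38 log units; beyond the scatter) from compound 3 to compound 4, 1.5-fold (0.18 log units) apart, within the scatter of two such steps. Among the compounds shown here, the change therefore carried from one core to the other without a detectable difference in its effect, but only the step on the core of compound 3 stands clear of the scatter, and two pairs do not make a rule for the whole series.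

The compounds shown leave open whether an amine, a carboxylic acid or a methoxy group in place of the hydroxyl would give numbers of this size in this assay. They also leave open how much each difference between the two cores, the placing of the chlorine and the pyridin-2-yl group against a phenyl group, contributes on its own.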